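Extending a Phenyl Tail to a Dimethoxyphenoxy Group

This account rests on a few compounds, and the source may have more. Where it says the series, first, only, none or still open, it means among the compounds named here.

Of the compounds shown here, three have been measured in an in vitro functional assay on HEK ts201 cells for antagonist activity at Neuronal acetylcholine receptor; alpha3/beta4 (Homo sapiens), read by fluorescence and calcium flux; on this read-out higher numbers stand for weaker inhibition and lower numbers for stronger inhibition. Compound 1 `CC1CC(=O)N(c2ccccc2C(=O)OCC2CCCN(CCCCCc3ccccc3)C2)C1=O` gives 4170 nM in this assay. Compound 2 `O=C(CCC1CCCNC1)c1ccccc1-c1ccccc1` gives 6610 nM in this assay, and compound 3 `O=C(Nc1cccc2ccccc12)c1ccccc1-c1ccccc1` gives 18200 nM in this assay. Compound 1 thus has the lowest of the three numbers, but compound 2 lies within the usual scatter of it, so the two cannot be ranked against each other; only compound 3 stands clearly apart, beyond the scatter. Going by the values given here, no pair of these measured compounds differs in a single place, so no single measured step can be drawn on.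

Compound 4 `COc1ccc(OCCCCCN2CCCC(COC(=O)c3ccccc3N3C(=O)CC(C)C3=O)C2)cc1OC` has not yet been measured in this assay. It differs from compound 1 in one place: 3,4-dimethoxyphenoxy in place of phenyl on a saturated chain carbon, five bonds along the chain from an amine nitrogen in a ring. Among the compounds with values here, the change sits at the far end of the chain from the shared core of compound 1, and nothing among the measured compounds tells how this assay responds to such a change. The reasonable expectation is therefore a step that stays within the scatter, in either direction. The estimated step from compound 1 to compound 4 is a 1.0-fold lower number from compound 1 to compound 4 (0.02 log units; within the scatter). Compound 4 is accordingly expected to give about 4000 nM in this assay, with a likely range from 1500 nM to 11000 nM.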

Compound 4, half-maximal inhibitory concentration: 2000000 nM
Compound 4: the middle estimate sits 500-fold (2.70 log units) below what was measured, outside the stated range (above it).
By their numbers in this assay, from the lowest: compounds 1 and 2 (each within the scatter of the next); then compound 3; then compound 4.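

In this assay, the far end of the chain turns out to matter a great deal: 3,4-dimethoxyphenoxy in place of phenyl on a saturated chain carbon, five bonds along the chain from an amine nitrogen in a ring, gives a 480-fold higher number from compound 1 to compound 4 (2.68 log units; beyond the scatter), with the shared core unchanged. Going by these compounds alone, the earlier compounds offered no single-place step, so this is the first direct sign that inhibition on this read-out depends on the group at this position, and this change makes it much weaker. The entering group keeps the carbon-only aromatic ring of phenyl while adding heavy atoms and hydrogen-bond acceptors, but nothing at hand explains the size of the step.

The change combines a linking oxygen with two methoxy groups, so the compounds shown leave open which of these parts accounts for the step, a question that a plain phenoxy group or a dimethoxyphenyl group at the same place would help to settle. They also leave open whether the same change would have a similar effect on a shorter chain.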